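A Second Chloro Substituent Added to Compound 3

This account rests on a few compounds, and the source may have more. Where it says the series, first, only, none or still open, it means among the compounds named here.

Compound 3 `O=C(O)Cc1sc(Cc2ccc(Cl)cc2)nc1-c1ccccc1` has the lowest number of the three compounds measured in an in vitro functional assay on HEK285-7 cells for antagonist activity at prostaglandin D2 receptor 2 (Homo sapiens), read by BRET and beta-arrestin recruitment (a higher number here means a weaker inhibitor, a lower number a stronger inhibitor), giving 580 nM. Compound 1 `COc1ccc(Nc2nc(-c3ccccc3)c(CC(=O)O)s2)cc1` stands nearest, with 1500 nM in this assay, and compound 2 `O=C(O)Cc1sc(Cc2ccccc2)nc1-c1ccc(Cl)cc1` gives 4100 nM; both gaps lie beyond the usual scatter. Compound 4 `O=C(O)Cc1sc(Cc2ccc(Cl)cc2)nc1-c1ccc(Cl)cc1` differs from compound 3 by chloro in place of hydrogen on an aromatic carbon, a change that reads, one bond further out, as phenyl to 4-chlorophenyl. Among the compounds with values here, no step between measured compounds isolates this change. Compound 2 carries the 4-chlorophenyl on the shared core and shows the highest number, but it differs from compound 3 in more than one place, so its value cannot be read as this change alone. The step of a 1.6-fold higher number from compound 3 to compound 4 (0.19 log units; within the scatter) is expected to be modest, pointing toward a somewhat higher number. Compound 4 is therefore estimated at 900 nM, within a range from 300 nM to 2700 nM.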

Compound 4, half-maximal inhibitory concentration: 220 nM
Compound 4: middle estimate off by 4.1-fold (0.61 log units), on the high side, outside the stated range (below it).
By their numbers in this assay, from the lowest: compound 4; then compound 3; then compound 1; then compound 2.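

In this assay, phenyl to 4-chlorophenyl gives a 2.6-fold lower number from compound 3 to compound 4 (0.42 log units; beyond the scatter), so on a compound already carrying chloro on its other aromatic ring, this change lowers the number. Compound 2 carries the same 4-chlorophenyl without that second chloro, and adding chloro on the other ring gives a 19-fold lower number from compound 2 to compound 4 (1.27 log units; beyond the scatter). Each chloro thus goes with a lower number in this pair of steps, the one on the other ring with the large step and the one at this position with the modest step.

No measured evidence here accounts for either step. From the compounds shown here alone, whether a methoxy group or an amine at this position would follow chloro remains open.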